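Adding a butoxy group to a weak PDE4A inhibitor

The source may report more compounds than this note shows. Statements on the series, on what has been measured and on what is new or still open speak of the compounds shown alone.

Measured compounds:
compound 1 `COc1ccc(C(=O)Nc2c(F)cccc2Cl)cc1OC1CCCC1` with 240 nM
compound 2 `COc1ccc(C(=O)Nc2c(F)cccc2F)cc1` with 37000 nM

In an assay on isolated protein for inhibition of phosphodiesterase 4A (Sus scrofa) (a higher number here means a weaker inhibitor, a lower number a stronger inhibitor), compound 2 gives the highest number of the two, and the gap to compound 1 lies far beyond the scatter. Compound 3 `CCCCOc1cc(C(=O)Nc2c(F)cccc2F)ccc1OC` is compound 2 with butoxy in place of hydrogen on an aromatic carbon, so that a butoxy stands on the aromatic carbon ortho to the methoxy group, where compound 1 carries its own ring-bearing ether. Among the measured compounds shown here, no single step measured between two compounds matches this change, but the difference between compound 1 and compound 2 suggests a large drop in this assay. Compound 3 is expected at 1000 nM, between 300 nM and 4000 nM, an estimated step of a 37-fold lower number from compound 2 to compound 3 (1.57 log units; beyond the scatter).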

Compound 3, half-maximal inhibitory concentration: 300 nM
Beside the measured number, compound 3's estimate is 3.3-fold (0.52 log units) above it; the measured number falls inside the stated range.
By their numbers in this assay, from the lowest: compounds 1 and 3 (each within the scatter of the next); then compound 2.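

Compounds 1 and 2 differ in more than one place, so their gap could not be tied to this position. In this assay, among the compounds shown here, the single change of hydrogen to butoxy, ortho to a methoxy group, gives a 120-fold lower number from compound 2 to compound 3 (2.09 log units; beyond the scatter), which places a large effect on this aromatic carbon. Since butoxy has no ring, an ether at this position need not carry a ring for a step of this size. As far as these compounds go, whether an ethoxy group, a hexyloxy chain or an amine here would give a similar step remains open. Nothing at hand explains the size of this step.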